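Working notes: cytotoxicity of compounds 1 to 3

The source may report more compounds than this note shows. Statements on the series, on what has been measured and on what is new or still open speak of the compounds shown alone.

Measured so far:
compound 1 `CCCCCCCCCCCCCCNC(=O)[C@H](CO)/N=C/c1cccc(Cl)c1`: 77000 nM
compound 2 `CCCCCCCCCCCCCCNC(=O)[C@H](CO)/N=C/c1ccccc1Cl`: 94900 nM

In an ADME assay on HEK293 cells (Homo sapiens) for cytotoxicity (a higher number here means a weaker inhibitor, a lower number a stronger inhibitor), compound 1 gives 77000 nM, the lowest of the two numbers shown, and compound 2 gives 94900 nM. Among the compounds with values here, the only measured step, a 1.2-fold higher number from compound 1 to compound 2 (0.09 log units; within the scatter), lies within the scatter, so the two values cannot be ordered. Within the data shown here, compound 3 `CCCCCCCCCCCCCCNC(=O)[C@H](CO)/N=C/c1ccccc1[N+](=O)[O-]` differs from compound 1 in the following way: 2-nitrophenyl in place of 3-chlorophenyl on a carbon with a double bond to nitrogen The one step that bears on a change at this ring is a 1.2-fold higher number from compound 1 to compound 2 (0.09 log units; within the scatter); it stayed within the scatter. No measured compound carries a nitrophenyl, so nothing shown supports a step beyond the scatter in either direction. The step expected from compound 1 to compound 3 is therefore a 1.1-fold higher number from compound 1 to compound 3 (0.04 log units; within the scatter), none beyond the scatter. Compound 3 is estimated in this assay at 85000 nM, with a range from 40000 nM to 180000 nM.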

Compound 3, half-maximal inhibitory concentration: 82600 nM
The estimate for compound 3 lay 1.0-fold (0.01 log units) above the measured number; measured number inside the range.
By their numbers in this assay, from the lowest: compounds 1, 3 and 2 (each within the scatter of the next).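

In this assay, within the data shown here, the change from a chloro to a nitro group on an aromatic carbon gives no step that can be told from the scatter: a 1.1-fold higher number from compound 1 to compound 3 (0.03 log units; within the scatter) and a 1.1-fold lower number from compound 2 to compound 3 (0.06 log units; within the scatter). Earlier, only the two chlorophenyl groups could be compared; now the 2-nitrophenyl group, with 2 hydrogen-bond acceptors against 0 for 3-chlorophenyl, also fits within the scatter at this position, on a carbon with a double bond to nitrogen. Nothing available explains why these three compounds cannot be separated.

As far as these compounds go, it remains open whether an amine or a carboxylic acid on this aromatic ring would give a step beyond the scatter. From the compounds shown here alone, it is also open whether a shorter chain in place of the shared one would change the number.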